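This account rests on a few compounds, and the source may have more. Where it says the series, first, only, none or still open, it means among the compounds named here.

Compound 1 `Nc1ccccc1NC(=O)/C=C/c1ccc(NCCNc2ccccc2)nc1`: 5000 nM
Compound 2 `Nc1ccccc1NC(=O)/C=C/c1ccc(CNc2ccccc2)cc1`: 11000 nM
Compound 3 `COc1cccc(NCc2ccc(/C=C/C(=O)Nc3ccccc3N)cc2)c1`: 10000 nM

In a functional assay on HCT-116 cells (Homo sapiens) for antiproliferative activity, read by MTT assay (on this read-out higher numbers stand for weaker inhibition and lower numbers for stronger inhibition), compound 3 stands second highest of the three numbers; its nearest neighbour is compound 2 and the furthest is compound 1, and both gaps lie within the scatter. Compound 4 `COc1ccc(NCc2ccc(/C=C/C(=O)Nc3ccccc3N)cc2)cc1OC` differs from compound 3 by methoxy in place of hydrogen on an aromatic carbon. Among the measured compounds shown here, the one measured step that bears on this change is a 1.1-fold lower number from compound 2 to compound 3 (0.04 log units; within the scatter), in which a methoxy set on an aromatic carbon left the number essentially unchanged. A second methoxy is therefore expected to do little, and the estimated step of a 1.1-fold lower number from compound 3 to compound 4 (0.05 log units; within the scatter) is expected to stay within the scatter. For compound 4 the estimate in this assay is 9000 nM, with a range from 4000 nM to 20000 nM.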

Compound 4, half-maximal inhibitory concentration: 5000 nM
The estimate for compound 4 lay 1.8-fold (0.26 log units) above the measured number; low and high end bracket the measured number.
By their numbers in this assay, from the lowest: compounds 1, 4, 3 and 2 (each within the scatter of the next, the first and the last beyond it).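

In this assay the methoxy added ortho to a methoxy group gives a 2.0-fold lower number from compound 3 to compound 4 (0.30 log units; within the scatter), so this single change cannot be read as a real gain. Among the compounds shown here, only the two methoxy groups taken together, as 3,4-dimethoxyphenyl in place of phenyl on the amine nitrogen, give a 2.2-fold lower number from compound 2 to compound 4 (0.34 log units; beyond the scatter), the first step in this set to pass the scatter, and a modest one. Nothing at hand explains this step. Going by these compounds, whether a fluorine or a hydroxyl on this aromatic carbon would give a step of similar size stays open.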